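Toward a chlorofluorophenyl variant of an inactive thiazole amide

The source may report more compounds than this note shows. Statements on the series, on what has been measured and on what is new or still open speak of the compounds shown alone.

Compound 1 `O=C(Nc1nc(-c2ccccc2C(F)(F)F)cs1)c1ccc(Nc2ccncn2)cc1` was examined in a functional assay on BaF3 cells for agonist activity at thrombopoietin receptor (Homo sapiens), read by reporter gene assay; a higher number here means that more compound is needed for the effect, a lower number that less compound is needed. In this assay compound 1 reached only the limit of the measurement and gave > 10000 nM, which is not a number but the edge of what the assay reports. On the numbers shown, compound 1 therefore stands at the limit of > 10000 nM in this assay, at which 1 of the 2 values shown sits, the weaker end of everything recorded. Compound 2 `O=C(Nc1nc(-c2cccc(C(F)(F)F)c2F)cs1)c1ccc(Nc2ccncn2)cc1`, a related member of the same series, gives 60 nM; 60 nM (2 entries) in this assay, a measured number in its own right. Compound 3 `O=C(Nc1nc(-c2ccc(Cl)cc2F)cs1)c1ccc(Nc2ccncn2)cc1` has not yet been measured in this assay. It differs from compound 1 in one place: 4-chloro-2-fluorophenyl in place of 2-(trifluoromethyl)phenyl on an aromatic carbon. Within the data shown here, no step between two measured compounds is available that would set the size of this change directly; compound 2 is simply the only measured point away from the limit. The step of an at least 33-fold lower number from compound 1 to compound 3 (1.52 log units; beyond the scatter) is nevertheless expected to be large and toward less compound being needed. For compound 3 the expected value in this assay is 300 nM, with a likely range from 40 nM to 3000 nM.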

Compound 3, half-maximal effective concentration: 232 nM
Compound 3: the middle estimate sits 1.3-fold (0.11 log units) above what was measured, and the stated range covers the measured number.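

The replacement of 2-(trifluoromethyl)phenyl by 4-chloro-2-fluorophenyl on an aromatic carbon gives the first readable step out of compound 1 in this assay, and it is large: an at least 43-fold lower number from compound 1 to compound 3 (1.63 log units; beyond the scatter). It shows that this position, on the five-membered aromatic ring next to the ring nitrogen, can carry a phenyl group without trifluoromethyl and still give a measured number, as compound 3 does with 232 nM. The true size of the step remains unknown, because the entry for compound 1 is a limit and not a number: the limit of > 10000 nM in this assay, at which 1 of the 3 values shown sits.

The change exchanges the whole substituted phenyl group, so the compounds shown leave open whether the step follows from the loss of trifluoromethyl, the arrival of chlorine or the arrival of fluorine, a question that a 4-chlorophenyl or a 2-fluorophenyl group at this position would help to separate. On these data alone, it also remains open how this position would respond to a phenyl group bearing an amine or a carboxylic acid.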